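Removing a hydroxyl from the benzyl group of a nitrofuran triazole

A few compounds are considered here, and "the series" means these few. Any claim that something is new, unique, unknown or untested is made for them only; others in the source may bear on it.

Measured compounds:
compound 1 `O=C(NCc1cn(Cc2ccc(C(F)(F)F)cc2)nn1)c1ccc([N+](=O)[O-])o1`, 321000 nM
compound 2 `COc1cc(Cn2cc(CNC(=O)c3ccc([N+](=O)[O-])o3)nn2)ccc1O`, 182000 nM

In an ADME assay on MRC5 cells (Homo sapiens) for cytotoxicity (a lower number here means a stronger inhibitor, a higher number a weaker inhibitor), compound 2 gives 182000 nM, the lowest of the two numbers, and compound 1 gives 321000 nM; the gap between them lies within the scatter, so the two compounds cannot be told apart on this read-out. Compound 3 `COc1ccc(Cn2cc(CNC(=O)c3ccc([N+](=O)[O-])o3)nn2)cc1` has not been measured in this assay. It differs from compound 2 in one place: 4-methoxyphenyl in place of 4-hydroxy-3-methoxyphenyl on a saturated chain carbon bound to an aromatic nitrogen. Among the measured compounds shown here, no step between measured compounds covers this change. Both measured values sit far up the concentration range, and the change is small, so the expected step of a 1.2-fold higher number from compound 2 to compound 3 (0.08 log units; within the scatter) in this assay is none beyond the scatter, in no particular direction. Compound 3 is therefore expected to give about 220000 nM in this assay, somewhere between 80000 nM and 600000 nM.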

Compound 3, half-maximal inhibitory concentration: 146000 nM
Compound 3: middle estimate off by 1.5-fold (0.18 log units), on the high side, and the stated range covers the measured number.
By their numbers in this assay, from the lowest: compounds 3, 2 and 1 (each within the scatter of the next, the first and the last beyond it).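

Exchanging 4-hydroxy-3-methoxyphenyl for 4-methoxyphenyl on a saturated chain carbon bound to an aromatic nitrogen leaves no readable change in this assay (a 1.2-fold lower number from compound 2 to compound 3 (0.10 log units; within the scatter)), so on this read-out the position accepts the loss of the hydroxyl and its hydrogen-bond donor. Among the compounds shown here, compound 3 also provides the first step that lies beyond the scatter, a modest one, with methoxy in place of trifluoromethyl on an aromatic carbon (a 2.2-fold lower number from compound 1 to compound 3 (0.34 log units; beyond the scatter)). No measurement offered here accounts for either step.

From the compounds shown here alone, whether an amine or a carboxylic acid on that aromatic carbon would move the number further remains open. So does whether a longer chain in place of the single saturated carbon would shift it at all.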